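The compounds below may be only part of what the source reports. "The series", "measured", "known", "first", "only" and "open" are said of these compounds alone.

Three compounds that share one core and differ only in the length of a saturated chain have been tested. Compound 1 `CCCCCCCCCCOC(=O)CCC(=O)N1CCN(CCCOc2cc3c(Nc4ccc(F)c(Cl)c4)ncnc3cc2OC)CC1` carries the shortest chain, compound 2 `CCCCCCCCCCCOC(=O)CCC(=O)N1CCN(CCCOc2cc3c(Nc4ccc(F)c(Cl)c4)ncnc3cc2OC)CC1` one carbon more, and compound 3 `CCCCCCCCCCCCCCOC(=O)CCC(=O)N1CCN(CCCOc2cc3c(Nc4ccc(F)c(Cl)c4)ncnc3cc2OC)CC1` a longer chain still. In a functional assay on A549 cells (Homo sapiens) for cytotoxicity, read by MTT assay, with a stated time of 24 h, tested at 60 uM (on this read-out lower numbers stand for a stronger effect and higher numbers for a weaker effect at the one concentration tested), compound 1 gives 3.9%, and compound 2 gives 3.9%, so the step of no change at the digits printed from compound 1 to compound 2 (within the scatter) is simply (methyl in place of hydrogen on a saturated chain carbon, ten or more bonds along the chain from an oxygen next to a carbonyl group). Compound 3 gives 84.9% in this assay, the weakest effect of the three, with a number 81 percentage points higher from compound 1 to compound 3 (beyond the scatter) for the change (butyl in place of hydrogen on a saturated chain carbon, ten or more bonds along the chain from an oxygen next to a carbonyl group), and likewise a number 81 percentage points higher from compound 2 to compound 3 (beyond the scatter).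

Compound 4 `CCCCCCCCCCCCCCCOC(=O)CCC(=O)N1CCN(CCCOc2cc3c(Nc4ccc(F)c(Cl)c4)ncnc3cc2OC)CC1` is the next member of the series, not yet measured. It differs from compound 3 by methyl in place of hydrogen on a saturated chain carbon, ten or more bonds along the chain from an oxygen next to a carbonyl group, the same change that was made from compound 1 to compound 2, at the same place. The cores of the two pairs differ by butyl in place of hydrogen on a saturated chain carbon, ten or more bonds along the chain from an oxygen next to a carbonyl group. For the measured compounds named here, the one earlier example of this change produced no shift, but it started from a strong effect, whereas compound 4 starts from the weak effect of compound 3. Going by the values given here, with no example of chain extension from such a starting point, the step from compound 3 to compound 4 is expected to be roughly a number 4.9 percentage points lower from compound 3 to compound 4 (within the scatter) in this assay. Compound 4 is therefore estimated to give about 80%, between 35% and 100%, the wide range reflecting how little is known beyond compound 3.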

Compound 4, a percentage reported as activity, at one concentration (the size of the read-out at that concentration, not a potency): 81.6%
Estimate against measurement, compound 4: 1.6 percentage points below; low and high end bracket the measured number.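

In this assay, for the compounds shown here, the methyl change gives a number 3.3 percentage points lower from compound 3 to compound 4 (within the scatter), so adding this one carbon to the chain leaves the read-out much the same on both cores, whether the starting effect is strong or weak: the same change on two cores in this assay, no change at the digits printed (within the scatter) from compound 1 to compound 2 and a number 3.3 percentage points lower (within the scatter) from compound 3 to compound 4, 3.3 percentage points apart, within the scatter of two such steps The larger butyl change also repeats, with a number 77.7 percentage points higher from compound 2 to compound 4 (beyond the scatter) closely matching its earlier example on the core of compound 1: the same change on two cores in this assay, a number 81 percentage points higher (beyond the scatter) from compound 1 to compound 3 and a number 77.7 percentage points higher (beyond the scatter) from compound 2 to compound 4, 3.3 percentage points apart, within the scatter of two such steps The pentyl change, a number 77.7 percentage points higher from compound 1 to compound 4 (beyond the scatter), has no second example to set beside it, and these comparisons show only that the steps agree within this small set of four compounds, not that they would hold on another core or why the read-out differs so sharply between the short-chain and long-chain pairs.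

The compounds shown leave open where the sharp difference sets in, since a chain longer than that of compound 2 but shorter than that of compound 3 does not appear among them. Also open, from the compounds shown here alone, is how a chain longer than that of compound 4, or a chain ending in an amine or a carboxylic acid, would behave in this assay.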